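The source may hold more compounds than are shown below. What is called first, only, known or untested is meant among the compounds shown, and "the series" means these compounds.

Measured so far in a functional assay on HCT-116 cells (Homo sapiens) for inhibition, read by sulforhodamine B assay; a higher number here means a weaker inhibitor, a lower number a stronger inhibitor:
- compound 1 `CC(C)(C)Nc1nc(C(Cl)(Cl)Cl)nc2ccccc12`: 25000 nM
- compound 2 `CC(C)(C)Nc1nc(C(F)(F)F)nc2ccccc12`: 20600 nM

Compound 2 stands level with compound 1 on these two numbers. Among the compounds with values here, the only measured step, a 1.2-fold lower number from compound 1 to compound 2 (0.08 log units; within the scatter), lies within the scatter, so neither compound can be ranked above the other.

Compound 3 `CC(C)(C)Nc1nc(C(F)(F)F)nc2ccc(O)cc12` differs from compound 2 by hydroxy in place of hydrogen on an aromatic carbon. The new group sits on a six-membered aromatic ring of carbon only, part of a fused system of two rings.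

The measured step bears on this change only weakly, as it concerns a different place on the shared core and a different exchange. Within the data shown here, no measured step covers a substitution at this place, so the size and direction of any effect in this assay are open. The working expectation therefore stays close to compound 2 at 20600 nM, with no step beyond the scatter and a wide margin on both sides.

The estimated step is a 1.4-fold lower number from compound 2 to compound 3 (0.14 log units; within the scatter).

For compound 3 the expected value is 15000 nM, within an estimated range of 4000 nM to 40000 nM.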

Compound 3, half-maximal inhibitory concentration: 7300 nM
Estimate against measurement, compound 3: 2.1-fold (0.31 log units) above, within the range that was stated.
By their numbers in this assay, from the lowest: compound 3; then compounds 2 and 1 (each within the scatter of the next).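

In this assay, within the data shown here, hydroxy in place of hydrogen on an aromatic carbon gives a 2.8-fold lower number from compound 2 to compound 3 (0.45 log units; beyond the scatter), whereas the exchange of trichloromethyl for trifluoromethyl gave a 1.2-fold lower number from compound 1 to compound 2 (0.08 log units; within the scatter), so this is the only one of the two steps that lies beyond the scatter. The carbon meta to a fused ring and para to a fused ring, on the six-membered aromatic ring of carbon only, is thus a place where a substitution on the shared core moves the number in this read-out, though only modestly. Nothing at hand accounts for the lower number at this place.

Going by these compounds, whether the step belongs to hydroxy itself or would also follow from another group on the same carbon stays open, and a methoxy group, an amine or a fluorine there would begin to separate these readings. On these data alone, it is also open whether hydroxy at this place gives a step of similar size with trichloromethyl on the core, as in compound 1, or at other carbons of the same ring.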